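A few compounds are considered here, and "the series" means these few. Any claim that something is new, unique, unknown or untested is made for them only; others in the source may bear on it.

Compound 1 `CCOC(=O)[C@@]12C[C@@H]1[C@@H](n1cnc3c(NC)nc(C#Cc4ccc(Br)s4)nc31)[C@H](O)[C@@H]2O`: 400 nM in an assay on HEK293 cells for binding affinity to sodium-dependent dopamine transporter (Homo sapiens), read by scintillation counting and radioligand binding, with stated times of 10 min and 90 min; a lower number here means that less compound is needed, a higher number that more compound is needed for the effect
Compound 2 `CNc1nc(C#Cc2ccc(Cl)s2)nc2c1ncn2[C@H]1[C@H](O)[C@H](O)[C@]2(C(=O)OC(C)C)C[C@H]12`: a limit, > 1000 nM in this assay

Compound 2 stands only at the limit of this assay; its value of > 1000 nM is a limit and not a number, the one given by the limit of > 1000 nM in this assay, at which 1 of the 2 values shown sits. Compound 3 `CCCCOC(=O)[C@@]12C[C@@H]1[C@@H](n1cnc3c(NC)nc(C#Cc4ccc(Cl)s4)nc31)[C@H](O)[C@@H]2O` shares the rest of its structure with compound 2 and differs by butyl in place of isopropyl on an oxygen next to a carbonyl group. Going by the values given here, no measured pair isolates this change, so neither its direction nor its size is known; a step within or only just beyond the usual scatter is expected. For compound 3 the expected step in this assay is a step that the limit leaves unreadable from compound 2 to compound 3. Compound 3 is estimated at 1500 nM, between 500 nM and 5000 nM, in this assay.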

Compound 3, half-maximal effective concentration: 1200 nM
Beside the measured number, compound 3's estimate is 1.3-fold (0.10 log units) above it, within the range that was stated.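

No step can be read from compound 2 to compound 3, as compound 2 stands at a limit and not at a number: the limit of > 1000 nM in this assay, at which 1 of the 3 values shown sits.

The compounds shown leave open the direction and size of the effect of butyl in place of isopropyl on an oxygen next to a carbonyl group.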